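Fluoro in place of hydrogen on compound 2

The source may hold more compounds than are shown below. What is called first, only, known or untested is meant among the compounds shown, and "the series" means these compounds.

Of the compounds shown here, two have numbers so far. In a functional assay on KYSE-450 cells (Homo sapiens) for inhibition, read by MTT assay, with a stated time of 48 h (on this read-out higher numbers stand for weaker inhibition and lower numbers for stronger inhibition), compound 1 (`COc1ccc(CNc2cc(OC)c(OC)c(OC)c2)cc1F`) gives 46200 nM and compound 2 (`C/C=C/C(=O)N(Cc1ccc(OC)cc1)c1cc(OC)c(OC)c(OC)c1`) gives 420 nM as the lower of the two numbers. Compound 2 therefore stands lowest on the numbers shown, and its gap to compound 1 lies beyond the scatter of repeated measurements.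

Compound 3 (`C/C=C/C(=O)N(Cc1ccc(OC)c(F)c1)c1cc(OC)c(OC)c(OC)c1`) departs from compound 2 in one place: fluoro in place of hydrogen on an aromatic carbon (fluoro in place of hydrogen on an aromatic carbon, ortho to a methoxy group). The same difference reads 4-methoxyphenyl to 3-fluoro-4-methoxyphenyl. Within the data shown here, no measured pair differs by this change alone, so the data hold no direct measure of it, and the starting point is the value of compound 2 (420 nM). No step beyond the scatter is expected in this assay and no direction is favoured. The expected size of the change a 1.1-fold lower number from compound 2 to compound 3 (0.02 log units; within the scatter) is small, and this remains an estimate resting on very few data. Compound 3 is estimated at 400 nM (expected range 150 nM to 1100 nM).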

Compound 3, half-maximal inhibitory concentration: 1400 nM
Compound 3: the middle estimate sits 3.5-fold (0.54 log units) below what was measured, outside the stated range (above it).
By their numbers in this assay, from the lowest: compound 2; then compound 3; then compound 1.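

In this assay, among these compounds, fluoro in place of hydrogen on the aromatic carbon ortho to a methoxy group gives the first direct reading of this change (a 3.3-fold higher number from compound 2 to compound 3 (0.52 log units; beyond the scatter)), which shows that this position of the 4-methoxyphenyl group responds to even a single added fluorine, and in the direction of weaker inhibition. The second reading concerns the nitrogen on the aromatic ring: (prop-1-en-1-yl)carbonyl in place of hydrogen there gives a 33-fold lower number from compound 1 to compound 3 (1.52 log units; beyond the scatter) with the 3-fluoro-4-methoxyphenyl group held constant, so the gain from this group on the nitrogen holds with fluoro present. No measurement shown here accounts for the loss at the fluoro position.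

The compounds shown leave open whether this loss is particular to fluoro or would also appear with chloro, a methyl group or a hydroxyl group on the same aromatic carbon. Also open, going by these compounds, is how far the gain at the nitrogen depends on the (prop-1-en-1-yl)carbonyl group itself rather than on an acetyl group or a longer chain on the carbonyl, and whether the fluoro step keeps its size with any of these.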